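This account rests on a few compounds, and the source may have more. Where it says the series, first, only, none or still open, it means among the compounds named here.

Compound 1 `CC1=CC[C@H](C(C)(C)NC(=S)N/N=C/c2ccc(O)cc2)CC1` is a thiosemicarbazone built from a terpene-derived amine and a hydroxy-substituted benzaldehyde. In a functional assay on OVCAR-3 cells (Homo sapiens) for inhibition, read by sulforhodamine B assay, with a stated time of 48 h (on this read-out lower numbers stand for stronger inhibition of growth and higher numbers for weaker inhibition of growth), compound 1 reaches only a limit of the assay, > 100000 nM, so no number is known for it. Two close relatives have been tested the same way. Compound 2 `CC1=CC[C@H](C(C)(C)NC(=S)N/N=C/c2ccc(N(C)C)cc2)CC1` carries a dimethylamino group in place of the hydroxy group on the aromatic carbon; in this assay compound 2 also sits at a limit, > 100000 nM. Compound 3 `COc1cc(/C=N/NC(=S)NC(C)(C)[C@H]2CC=C(C)CC2)ccc1O` adds a methoxy group to the ring; in this assay compound 3 likewise gives a limit, > 100000 nM. Because of this the limit of > 100000 nM in this assay, at which 3 of the 3 values shown sit, the steps a step that the two limits leave unreadable from compound 1 to compound 2 and a step that the two limits leave unreadable from compound 1 to compound 3 cannot be read. Compound 4 `CC1=CC[C@H](C(C)(C)NC(=S)N/N=C/c2ccc[nH]2)CC1` changes the aromatic part instead: 1H-pyrrol-2-yl in place of 4-hydroxyphenyl on a carbon with a double bond to nitrogen. Within the data shown here, no measured step bears on this exchange, and nothing here suggests movement beyond the scatter. Compound 4 is therefore expected to give 150000 nM, with a range from 30000 nM to 600000 nM. The step that the limit leaves unreadable from compound 1 to compound 4 is expected to be essentially none.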

Compound 4, concentration for total growth inhibition: > 100000 nM
Compound 4: only a limit was reported (the forecaster's own chance of this, stated with the estimate: 75%); the middle value lies beyond the limit too.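

Compound 1 and compound 4 both stop at a limit rather than a number, so no step can be read for the exchange of 4-hydroxyphenyl for 1H-pyrrol-2-yl: the limit of > 100000 nM in this assay, at which 4 of the 4 values shown sit.

The compounds shown leave open whether these aromatic parts differ at all in their inhibition of growth.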